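The compounds below may be only part of what the source reports. "The series", "measured", "known", "first", "only" and "open" are said of these compounds alone.

Of the three compounds sharing one core, compound 1 `COc1cc(C(=O)/C=C/c2c[nH]c3ccccc23)cc([N+](=O)[O-])c1OC` and compound 2 `COc1cc(C(=O)/C=C/c2c[nH]c3ccccc23)cc(SC)c1OC` have been measured, while compound 3 `COc1cc(C(=O)/C=C/c2c[nH]c3ccccc23)cc(N)c1OC` has not. In a functional assay on MCF7 cells (Homo sapiens) for antiproliferative activity, read by MTT assay, with a stated time of 48 h (on this read-out lower numbers stand for stronger inhibition and higher numbers for weaker inhibition), compound 1 gives 1290 nM and compound 2 gives 186 nM as the lower of the two numbers. The step to compound 3 puts amino in place of methylsulfanyl on an aromatic carbon, ortho to a methoxy group (amino in place of methylsulfanyl on an aromatic carbon). Going by the values given here, only one measured step bears on this carbon: a 6.9-fold lower number from compound 1 to compound 2 (0.84 log units; beyond the scatter) when methylsulfanyl took the place of nitro. Among the compounds with values here, that step lies beyond the scatter, so the read-out does respond to a change at this carbon, but no compound here shows what amino does. Within the data shown here, with compound 2 at 186 nM as the lower of only two numbers, a modest move towards a higher number seems more likely than a further fall, and a result within the scatter would not surprise. An estimated step of a 1.9-fold higher number from compound 2 to compound 3 (0.27 log units; within the scatter) is expected here. In this assay the estimate for compound 3 is 350 nM with 80 nM to 1500 nM as the expected range.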

Compound 3, half-maximal inhibitory concentration: 595 nM
Estimate against measurement, compound 3: 1.7-fold (0.23 log units) below; the measured number falls inside the stated range.
By their numbers in this assay, from the lowest: compound 2; then compound 3; then compound 1.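

In this assay, the step from methylsulfanyl to amino is a change in its own right: a 3.2-fold higher number from compound 2 to compound 3 (0.51 log units; beyond the scatter), and a 2.2-fold lower number from compound 1 to compound 3 (0.34 log units; beyond the scatter), both beyond the scatter. The earlier pair showed only that the read-out responds to a change at this carbon, whereas the three groups now form an order among these compounds, with methylsulfanyl giving the lowest number, amino an intermediate one and nitro the highest. Amino is the smaller of the two groups in the new step and brings a hydrogen-bond donor that methylsulfanyl lacks, but no measurement shown here links either difference to the rise in the number, and nothing offered explains the order.

The three compounds cannot show whether the low number of compound 2 depends on the sulfur or on its attached methyl, which a comparison with ethylsulfanyl or methoxy at this carbon could begin to separate. On these data alone, it also remains open whether substituting the amino group, as in dimethylamino or an acetamide, would move the number towards that of compound 2 or away from it.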